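This account rests on a few compounds, and the source may have more. Where it says the series, first, only, none or still open, it means among the compounds named here.

Measured so far:
Compound 1, `C=CCn1c(=O)/c(=C\c2ccccc2Cl)[nH]c(=O)/c1=C\c1ccccc1OC`: 9200 nM
Compound 2, `C=CCn1c(=O)/c(=C\c2cccc(Cl)c2Cl)[nH]c(=O)/c1=C\c1ccccc1OC`: 4500 nM

Both compounds were tested in a functional assay on NCI-H1975 cells (Homo sapiens) for cytotoxicity, read by CCK-8 assay, with a stated time of 72 h; on this read-out lower numbers stand for stronger inhibition and higher numbers for weaker inhibition. Compound 2 stands at the lowest of the two numbers; its nearest neighbour is compound 1, separated by a 2.0-fold lower number from compound 1 to compound 2 (0.31 log units; beyond the scatter), a step brought about by chloro in place of hydrogen on an aromatic carbon. Compound 3, `C=CCn1c(=O)/c(=C\c2ccc(F)c(Br)c2)[nH]c(=O)/c1=C\c1ccccc1OC`, has not yet been measured. It differs from compound 2 in one place: 3-bromo-4-fluorophenyl in place of 2,3-dichlorophenyl on a double-bonded chain carbon bound to an aromatic carbon. For the measured compounds named here, no measured step bears directly on this change. Going by the values given here, the single step available concerns a chloro added to a ring that otherwise stays the same, whereas in compound 3 the whole ring is exchanged for one carrying two different halogens, so its size gives only a rough sense of how much a change in halogen pattern on this ring can move the number. With nothing closer to anchor it, compound 3 is expected to give about 6000 nM in this assay, within a range of 2500 nM to 15000 nM. The step this estimate implies, a 1.3-fold higher number from compound 2 to compound 3 (0.12 log units; within the scatter), is expected to stay close to the scatter.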

Compound 3, half-maximal inhibitory concentration: "not active" (no number reported)
For compound 3 the study gives words and no number, so the estimate cannot be set against anything.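

In this assay, for the compounds shown here, compound 3 is reported only in words, as not active, so no step from compound 2 to compound 3 can be read. Nothing available bears on why this result arose. The compounds shown leave open how far 3-bromo-4-fluorophenyl in place of 2,3-dichlorophenyl moves the number, and which of its two halogens matters.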